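Aryl swap on the amide arm of compound 2

This account rests on a few compounds, and the source may have more. Where it says the series, first, only, none or still open, it means among the compounds named here.

Of the compounds shown here, two have been measured in a functional assay on U-937 cells (Homo sapiens) for cytotoxicity, read by MTT assay, with a stated time of 24 h; on this read-out higher numbers stand for weaker inhibition and lower numbers for stronger inhibition. Compound 2 `Nc1nn(Cc2cn(CC(=O)Nc3c(F)cccc3F)nn2)c2nc(-c3ccccc3)cc(C(F)(F)F)c12` gives 30.6 ug/mL in this assay, and compound 1 `CCCCCCCCCCn1cc(Cn2nc(N)c3c(C(F)(F)F)cc(-c4ccccc4)nc32)nn1` gives 27.1 ug/mL, the two numbers within the scatter of each other. Going by the values given here, the single available step, a 1.1-fold higher number from compound 1 to compound 2 (0.05 log units; within the scatter), exchanged the whole nonyl chain for the (2,6-difluorophenyl)carbamoyl arm without moving the number beyond the scatter. Compound 3 `Nc1nn(Cc2cn(CC(=O)Nc3ccc(F)cc3Br)nn2)c2nc(-c3ccccc3)cc(C(F)(F)F)c12` is not yet measured; it differs from compound 2 by 2-bromo-4-fluorophenyl in place of 2,6-difluorophenyl on an amide-type nitrogen, the place being an amide-type nitrogen whose other neighbour is a carbonyl carbon. Among the compounds with values here, no measured step touches the aryl group on that nitrogen, so the only guide is that a much larger rebuild of the same arm left the number unchanged. Compound 3 is therefore expected to show no step beyond the scatter, a 1.0-fold lower number from compound 2 to compound 3 (0.01 log units; within the scatter). The estimate for compound 3 in this assay is 30 ug/mL, with a range of 12 ug/mL to 65 ug/mL.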

Compound 3, half-maximal inhibitory concentration: 98.3 ug/mL
The estimate for compound 3 lay 3.3-fold (0.52 log units) below the measured number, and the stated range ends below it.
By their numbers in this assay, from the lowest: compounds 1 and 2 (each within the scatter of the next); then compound 3.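

In this assay, going by these compounds alone, the aryl group on the amide-type nitrogen is a place where the number responds: 2-bromo-4-fluorophenyl in place of 2,6-difluorophenyl gives a 3.2-fold higher number from compound 2 to compound 3 (0.51 log units; beyond the scatter), the first step beyond the scatter. The arm is therefore not indifferent to what it carries, for the exchange of nonyl that stayed within the scatter with the 2,6-difluorophenyl arm gives a 3.6-fold higher number from compound 1 to compound 3 (0.56 log units; beyond the scatter) with the 2-bromo-4-fluorophenyl arm. No measurement at hand bears on the reason for this rise.

The swap alters the halogens and their placement together, so the bromine and the relocated fluorine cannot be separated on these compounds. Also open, from the compounds shown here alone, is how a plain phenyl or a 2-chloro-4-fluorophenyl group on the same nitrogen would read.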